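This account rests on a few compounds, and the source may have more. Where it says the series, first, only, none or still open, it means among the compounds named here.

In a functional assay on CHO cells for antagonist activity at metabotropic glutamate receptor 5 (Homo sapiens), read by calcium flux; a lower number here means a stronger inhibitor, a higher number a weaker inhibitor:
compound 1 `Cc1c(C(C)OC(=O)NC2CCCCC2)oc2ncnn12`: 3160 nM
compound 2 `Cc1c(C(C)OC(=O)Nc2ccccc2)oc2ncnn12`: 63.1 nM
compound 3 `Cc1c(C(C)OC(=O)Nc2cccc(Cl)c2)oc2ncnn12`: 39.8 nM

Compound 3 gives the lowest of the three numbers; compound 2 sits within the scatter of it, while compound 1 is far higher, as a 79-fold lower number from compound 1 to compound 3 (1.90 log units; beyond the scatter) and a 50-fold lower number from compound 1 to compound 2 (1.70 log units; beyond the scatter) show. Compound 4 `Cc1c(C(C)OC(=O)Nc2ccc(Cl)cc2)oc2ncnn12` differs from compound 3 by 4-chlorophenyl in place of 3-chlorophenyl on an amide-type nitrogen. Within the data shown here, no measured step moves the chloro group on the ring. Among the measured compounds shown here, the only step that touches it, a 1.6-fold lower number from compound 2 to compound 3 (0.20 log units; within the scatter), was within the scatter, and both steps starting from compound 1 involve the change from cyclohexyl to an aromatic ring, which compound 4 keeps. A step within the scatter in this assay is therefore expected, with a 1.3-fold higher number from compound 3 to compound 4 (0.10 log units; within the scatter). For compound 4 the estimate is 50 nM, in the range 15 nM to 160 nM.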

Compound 4, half-maximal inhibitory concentration: 2510 nM
Estimate against measurement, compound 4: 50-fold (1.70 log units) below, outside the stated range (above it).
By their numbers in this assay, from the lowest: compounds 3 and 2 (each within the scatter of the next); then compounds 4 and 1 (each within the scatter of the next).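

In this assay, among these compounds, moving the chloro group matters far more than adding it: 4-chlorophenyl in place of 3-chlorophenyl gives a 63-fold higher number from compound 3 to compound 4 (1.80 log units; beyond the scatter) in the first measured step that moves this group. Chloro in place of hydrogen therefore has no single outcome on this ring, since a 40-fold higher number from compound 2 to compound 4 (1.60 log units; beyond the scatter) stands against the step within the scatter that gave compound 3. An aromatic ring on the amide-type nitrogen is also not enough for a low number, as a 1.3-fold lower number from compound 1 to compound 4 (0.10 log units; within the scatter) leaves 4-chlorophenyl level with cyclohexyl.

Nothing available bears on the cause of this result. From the compounds shown here alone, whether fluoro or methoxy in place of the chloro of 4-chlorophenyl also gives a high number stays open.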